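The source may report more compounds than this note shows. Statements on the series, on what has been measured and on what is new or still open speak of the compounds shown alone.

Compound 1 `CC(=O)OCC(C)(C)NC(=O)N(CCC1CCN(Cc2ccc(C)cc2)CC1)Cc1ccc(-c2ccc(F)cc2)cc1` is the reference point for this set. For the measured compounds named here, in an in vitro functional assay on HEK293 cells for antagonist activity at melanin-concentrating hormone receptor 1 (Homo sapiens), read by GTPgammaS binding, with a stated time of 45 min (on this read-out higher numbers stand for higher potency (the scale is a negative logarithm) and lower numbers for lower potency), compound 1 gives 6.39, the second highest of the three numbers measured so far, though every pairwise step lies within the scatter. Compound 3 `CC(=O)OCC(C)(C)NC(=O)N(CCC1CCN(Cc2ccc(C)cc2)CC1)Cc1ccc(-c2ccccc2)cc1` gives 6.44 and compound 2 `COc1ccc(-c2ccc(CN(CCC3CCN(Cc4ccc(C)cc4)CC3)C(=O)NC(C)(C)COC(C)=O)cc2)cc1` gives 6.19. The step of a number 0.05 log units higher from compound 1 to compound 3 (within the scatter) and the step of a number 0.20 log units lower from compound 1 to compound 2 (within the scatter) are both within the scatter, as is a number 0.25 log units higher from compound 2 to compound 3 (within the scatter); exchanging the substituent on an aromatic carbon of the biaryl end changes nothing that can be resolved.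

Compound 4 `CCC(CO)(CO)NC(=O)N(CCC1CCN(Cc2ccc(C)cc2)CC1)Cc1ccc(-c2ccc(F)cc2)cc1` instead alters the urea substituent: 1,1-bis(hydroxymethyl)propyl in place of 1-(acetoxymethyl)-1-methylethyl on an amide-type nitrogen. The group that leaves has 8 heavy atoms and no hydrogen-bond donor; the group that enters has 7 heavy atoms and 2 hydrogen-bond donors. Going by the values given here, no measured step touches this nitrogen; all three concern an aromatic carbon elsewhere, so none bears on the change. With no guide, the expected step of a number 0.09 log units lower from compound 1 to compound 4 (within the scatter) is set at none beyond the scatter, with a wide range. Compound 4 is therefore expected to give 6.3, between 5.7 and 6.9.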

Compound 4, negative logarithm of the antagonist equilibrium constant: 6.54
Beside the measured number, compound 4's estimate is 0.24 log units below it, within the range that was stated.
By their numbers in this assay, from the lowest: compounds 2, 1, 3 and 4 (each within the scatter of the next, the first and the last beyond it).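

At the amide-type nitrogen, 1,1-bis(hydroxymethyl)propyl in place of 1-(acetoxymethyl)-1-methylethyl gives, in this assay, a number 0.15 log units higher from compound 1 to compound 4 (within the scatter). The urea substituent can therefore be exchanged here without a resolvable change, although the entering group has 2 hydrogen-bond donors and the leaving group has none, and the double bond outside aromatic rings is lost, so the acetoxy ester is not required for a value in this range in this pair. No measurement at hand bears on why the two groups read alike.

From the compounds shown here alone, whether both hydroxymethyl arms are needed remains open, as does the outcome with a single hydroxymethyl arm, a primary amine or a carboxylic acid on this carbon. The pair also leaves open whether this exchange reads the same with the other biaryl substituents, hydrogen or methoxy.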